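The compounds below may be only part of what the source reports. "The series", "measured", "known", "first", "only" and "open" are said of these compounds alone.

Compound 1 `COc1ccc2c(=O)c(/C=C/C(=O)Nc3ccc(Cl)cc3)coc2c1` carries a methoxy group on its shared core and a 4-chlorophenyl amide at the end of the unsaturated chain. In a functional assay on HeLa cells (Homo sapiens) for inhibition, read by MTT assay, with a stated time of 48 h (on this read-out higher numbers stand for weaker inhibition and lower numbers for stronger inhibition), compound 1 gives only a limit, > 100000 nM, and not a number (the limit of > 100000 nM in this assay, at which 1 of the 3 values shown sits). Two other compounds share the core but bear a hydroxy group in place of the methoxy. Compound 2 `Cc1ccccc1NC(=O)/C=C/c1coc2cc(O)ccc2c1=O` gives 8670 nM in this assay. For the measured compounds named here, compound 3 `O=C(/C=C/c1coc2cc(O)ccc2c1=O)Nc1ccccc1` gives 9700 nM in this assay, and the step of a 1.1-fold higher number from compound 2 to compound 3 (0.05 log units; within the scatter) is the only measured step, involving hydrogen in place of methyl on an aromatic carbon.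

Compound 4 `COc1ccc(NC(=O)/C=C/c2coc3cc(OC)ccc3c2=O)cc1` differs from compound 1 in one place: methoxy in place of chloro on an aromatic carbon. Going by the values given here, no measured step concerns a change of this kind, and the one measured step touches a different position on compounds with the hydroxy core. Compound 1 sits at the limit, so there is no number from which a step could be read. The estimate for compound 4 is therefore that it stays near the limit, expected at 100000 nM, with a range from 30000 nM to 300000 nM, meaning an expected step of a number no higher from compound 1 to compound 4 (the limit leaves the size open).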

Compound 4, half-maximal inhibitory concentration: 13000 nM
Compound 4: middle estimate off by 7.7-fold (0.89 log units), on the high side; the measured number lies below the stated range.
By their numbers in this assay, from the lowest: compounds 2, 3 and 4 (each within the scatter of the next). At a limit, above all of these: compound 1.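

On the methoxy core, the group at the end of the chain clearly matters: going from 4-chlorophenyl to 4-methoxyphenyl gives an at least 7.6-fold lower number from compound 1 to compound 4 (0.88 log units; beyond the scatter) in this assay. For the compounds shown here, the earlier compounds could not show this, as their one measured step concerned a different position on the hydroxy core and stayed within the scatter. The full size of the new step remains unknown because compound 1 gives only a limit and not a number: the limit of > 100000 nM in this assay, at which 1 of the 4 values shown sits.

Still open, going by these compounds, is how hydrogen, an amine or a carboxylic acid at this place on the methoxy core would read, and so whether the shift belongs to the loss of chloro or the arrival of methoxy. Also open, on these data alone, is whether the same change would have a similar effect on the hydroxy core of compound 2 and compound 3.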